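This account rests on a few compounds, and the source may have more. Where it says the series, first, only, none or still open, it means among the compounds named here.

Of the compounds shown here, two built on the shared core have been measured so far. In a functional assay on MOLT-4 cells (Homo sapiens) for inhibition, read by sulforhodamine B assay, with a stated time of 48 h, tested at 10 uM (a lower number here means less inhibition, a higher number more inhibition at the concentration tested (going by the name of the read-out)), compound 1 `O=Cc1ccc(-c2cn3ccnc3c(-c3ccc4ncn(C5CCCCC5)c4c3)n2)cc1` gives 58.7%. In this assay compound 2 `CCc1ccc(-c2cn3ccnc3c(-c3ccc4ncn(Cc5ccccc5)c4c3)n2)cc1` gives 54.2%, the lower of the two numbers, although compound 1 lies within the usual scatter of it, so the two are not told apart by these readings.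

Compound 3 `c1ccc(Cn2cnc3ccc(-c4nc(-c5cccc6ccccc56)cn5ccnc45)cc32)cc1` has not yet been measured. Against compound 2 it shows one change: naphthalen-1-yl in place of 4-ethylphenyl on an aromatic carbon. For the measured compounds named here, no step between two measured compounds is available to anchor what this change does, so the expectation rests on compound 2 alone. The step of a number 2.2 percentage points lower from compound 2 to compound 3 (within the scatter) is expected to be small, with no direction that can be called beyond the scatter. Compound 3 is therefore estimated to give 52% in this assay, with a range from 30% to 74%.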

Compound 3, a percentage reported as inhibition, at one concentration (the size of the read-out at that concentration, not a potency): 22.3%
Beside the measured number, compound 3's estimate is 29.7 percentage points above it, and the stated range ends above it.
By their numbers in this assay, from the lowest: compound 3; then compounds 2 and 1 (each within the scatter of the next).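

Putting naphthalen-1-yl in place of 4-ethylphenyl gives a number 31.9 percentage points lower from compound 2 to compound 3 (beyond the scatter) in this assay. This is the first step shown at this position, on an aromatic carbon next to the ring nitrogen, and it shows that the reading depends on the group placed there, even though both groups are all carbon, with no hydrogen-bond donors or acceptors and no net charge. Nothing measured here accounts for the size of this step.

The compounds shown leave open whether the second aromatic ring of naphthalen-1-yl alone goes with the lower reading, or whether naphthalen-2-yl or an unsubstituted phenyl would read differently. They also leave open how the reading responds at this position to an amine or a carboxylic acid on the phenyl ring.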